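Cyclopentyl in place of butyl on a sulfonyl chain

A few compounds are considered here, and "the series" means these few. Any claim that something is new, unique, unknown or untested is made for them only; others in the source may bear on it.

Values in a functional assay, read by fluorescence and spectrophotometry, with a stated time of 1 h (on this read-out higher numbers stand for an effect only at larger amounts of compound and lower numbers for an effect already at smaller amounts), follow.
compound 1 `O=S(=O)(/C=C/c1ccc(O)c(O)c1)CCCCCCCCO` gives 6700 nM
compound 2 `O=S(=O)(/C=C/c1ccc(O)c(O)c1)CC1CCCO1` gives 10500 nM
compound 3 `CCCCCCCS(=O)(=O)/C=C/c1ccc(O)c(O)c1` gives 7100 nM

All three compounds share one core and differ only in the saturated chain. Compound 3 at 7100 nM lies within the scatter of both other compounds, so its place among the three numbers carries no real order.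

The next compound is compound 4 (`O=S(=O)(/C=C/c1ccc(O)c(O)c1)CCCC1CCCC1`), and its difference from compound 3 is cyclopentyl in place of butyl on a saturated chain carbon, three bonds along the chain from a sulfonyl sulfur which in words means cyclopentyl in place of butyl on a saturated chain carbon, three bonds along the chain from a sulfonyl sulfur. The same change can be read as hexyl to 2-cyclopentylethyl.

Among the compounds with values here, no measured compound carries cyclopentyl, so the evidence is indirect. Hexyl in place of oxolan-2-yl gave a 1.5-fold lower number from compound 2 to compound 3 (0.17 log units; within the scatter) and hydrogen in place of hydroxymethyl gave a 1.1-fold higher number from compound 1 to compound 3 (0.03 log units; within the scatter) and so no step beyond the scatter is expected in this assay for compound 4 in either direction. The expected step is a 1.1-fold higher number from compound 3 to compound 4 (0.02 log units; within the scatter) and it is an estimate only. Compound 4 is estimated at 7500 nM within an expected range of 3800 nM to 15000 nM in four of five measurements.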

Compound 4, half-maximal effective concentration: 6300 nM
Estimate against measurement, compound 4: 1.2-fold (0.08 log units) above, and the stated range covers the measured number.
By their numbers in this assay, from the lowest: compounds 4, 1, 3 and 2 (each within the scatter of the next).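

In this assay, within the data shown here, cyclopentyl in place of butyl, three bonds along the chain from a sulfonyl sulfur, gives a 1.1-fold lower number from compound 3 to compound 4 (0.05 log units; within the scatter) and so a ring of carbon only at this place cannot be told apart from the open chain; the only ring among the earlier compounds was oxolan-2-yl, so this is new. Among these compounds, the wider comparisons agree, with a 1.1-fold lower number from compound 1 to compound 4 (0.03 log units; within the scatter) when cyclopentyl takes the place of 5-hydroxypentyl and a 1.7-fold lower number from compound 2 to compound 4 (0.22 log units; within the scatter) when 2-cyclopentylethyl takes the place of oxolan-2-yl, and thus neither the terminal hydroxyl nor the ring oxygen of the earlier compounds separates from the all-carbon ring on this read-out. No other measurement bearing on this result is available to help interpret it.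

With every printed step inside the scatter, the compounds shown do not reveal whether any change to this chain can move the number at all. From the compounds shown here alone, an amine or a carboxylic acid at the chain end, a phenyl ring in place of cyclopentyl, or a much longer chain could each test that, and how any of them would read here remains open.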